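Removing One Hydroxy Group From a Weak Acid

The source may hold more compounds than are shown below. What is called first, only, known or untested is meant among the compounds shown, and "the series" means these compounds.

Compound 1 `O=C(O)/C=C/c1cn(-c2ccc(O)cc2)nc1-c1ccc(O)cc1`: > 100000 nM
Compound 2 `O=Cc1cn(-c2ccc(O)cc2)nc1-c1cc(O)ccc1O`: 43000 nM

Both results come from a functional assay (Mus musculus) for inhibition, with a stated time of 5 days; on this read-out higher numbers stand for weaker inhibition and lower numbers for stronger inhibition. For compound 1 the value > 100000 nM is only a limit of the assay, not a measured number (the limit of > 100000 nM in this assay, at which 1 of the 2 values shown sits). Compound 2 gives 43000 nM in this assay. No step between these two measured compounds is shown, so only their separate values can be stated.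

Compound 3 `O=C(O)/C=C/c1cn(-c2ccc(O)cc2)nc1-c1ccccc1` differs from compound 1 by hydrogen in place of hydroxy on an aromatic carbon. Since compound 1 sits at the limit, the expected step is a step that the limit leaves unreadable from compound 1 to compound 3, meaning none beyond the scatter. Compound 3 is expected to give 150000 nM in this assay, most likely between 40000 nM and 600000 nM, with a good chance that again only a limit is reported.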

Compound 3, half-maximal inhibitory concentration: > 100000 nM
Compound 3 ended at the assay's limit (the forecaster's own chance of this, stated with the estimate: 70%); the middle value does not contradict the limit.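

In this assay, among the compounds shown here, compound 1 and compound 3 are both reported only as limits, and no step between them can be read. As far as these compounds go, whether going from 4-hydroxyphenyl to phenyl changes inhibition in this assay at all stays open.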